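Swapping the aryl group on the sulfonamide nitrogen

The compounds below may be only part of what the source reports. "The series", "measured", "known", "first", "only" and "open" are said of these compounds alone.

Measured compounds:
compound 2 `Cc1ccccc1NS(=O)(=O)c1cccc(CCCCCCNC(=O)/C=C/c2cccnc2)c1`: 5.08 nM
compound 1 `O=C(/C=C/c1cccnc1)NCCCCCCc1ccc(S(=O)(=O)Nc2ccccc2)cc1`: 14.4 nM

In an assay on isolated protein for inhibition of Nicotinamide phosphoribosyltransferase (Homo sapiens), read by WST assay, with stated times of 60 min, 5 min and 30 min, in the presence of a further agent that is not named here (a lower number here means a stronger inhibitor, a higher number a weaker inhibitor), compound 2 gives 5.08 nM, the lowest of the two numbers. Its nearest neighbour, compound 1, gives 14.4 nM in this assay, and the gap between the two lies beyond the usual scatter, so compound 2 is the stronger inhibitor of the pair. Within the data shown here, the two compounds differ in more than one place, so no single step between them is known.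

Compound 3 `CCc1ccc(NS(=O)(=O)c2cccc(CCCCCCNC(=O)/C=C/c3cccnc3)c2)cc1` has not yet been measured. It differs from compound 2 in one place: 4-ethylphenyl in place of 2-methylphenyl on a sulfonamide nitrogen. Among the measured compounds shown here, no measured pair shows what this change does, so the expectation rests on the closeness of the two known values alone. A modest step is expected, a 1.6-fold higher number from compound 2 to compound 3 (0.20 log units; within the scatter), toward a somewhat weaker inhibitor. Compound 3 is therefore estimated at 8 nM in this assay, within a range of 3 nM to 25 nM.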

Compound 3, half-maximal inhibitory concentration: 31.5 nM
Estimate against measurement, compound 3: 3.9-fold (0.60 log units) below; measured number above the stated range.
By their numbers in this assay, from the lowest: compound 2; then compound 1; then compound 3.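

In this assay the aryl group on the sulfonamide nitrogen proves to be a position that matters: 4-ethylphenyl in place of 2-methylphenyl gives a 6.2-fold higher number from compound 2 to compound 3 (0.79 log units; beyond the scatter), toward a weaker inhibitor. This is the first change in one place among these compounds, as compound 1 and compound 2 differ in more than one place. Both groups are six-membered aromatic rings of carbon only, with no hydrogen-bond donors or acceptors, and nothing measured here explains the shift.

The compounds shown leave open whether the step follows from the ethyl group itself or from where it sits on the ring, a question that 2-ethylphenyl or 4-methylphenyl on the same nitrogen would address. Also open, on these data alone, is how this position responds to a ring carrying an amine or a carboxylic acid.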